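The compounds below may be only part of what the source reports. "The series", "measured", "known", "first", "only" and "open" are said of these compounds alone.

In a functional assay for antagonist activity, with Cavia porcellus as the target (on this read-out higher numbers stand for weaker inhibition and lower numbers for stronger inhibition), compound 1 `CCN(CC)CC#CCCC1(C(O)(c2ccccc2)c2ccccc2)SCCCS1` gives 500 nM; 500 nM (2 entries) on both of its entries. Among the compounds with values here, compound 2 `CN(CC#CCCC1(C(O)(c2ccccc2)c2ccccc2)SCCCS1)Cc1ccccc1` gives 3170 nM as its only single number, with one further entry that gives none, and this is the higher number of the two, meaning weaker inhibition. Compound 3 `CN(CC#CCCC1(C(O)(c2ccccc2)c2ccccc2)SCCCS1)CCCc1ccccc1` has not yet been measured. Within the data shown here, it differs from compound 2 by phenethyl in place of phenyl on a saturated chain carbon bound to an amine nitrogen as its one change, phenethyl in place of phenyl on a saturated chain carbon bound to an amine nitrogen. Among the measured compounds shown here, no measured pair here differs in one place only, so the data offer no direct guide to this change. In this assay no shift beyond the usual scatter is expected, in either direction, and the estimated step of a 1.3-fold lower number from compound 2 to compound 3 (0.10 log units; within the scatter) reflects that. Compound 3 is expected at 2500 nM with an estimated range from 800 nM to 8000 nM in this read-out.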

Compound 3, antagonist equilibrium constant: 1630 nM
Compound 3: middle estimate off by 1.5-fold (0.19 log units), on the high side, and the stated range covers the measured number.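

In this assay, within the data shown here, this pair gives the first direct reading at this position: phenethyl in place of phenyl on a saturated chain carbon bound to an amine nitrogen gives a 1.9-fold lower number from compound 2 to compound 3 (0.29 log units; within the scatter). Going from benzyl to 3-phenylpropyl, with the same aromatic ring carried on a longer chain, therefore leaves the read-out without a change that can be told from the scatter. Nothing available gives a reason for this result.

This is a single pair, so it sets no trend for chain length at this position. Going by these compounds, it remains open whether a still longer chain such as 4-phenylbutyl, a cyclohexyl ring in place of the phenyl ring, or a pyridyl ring at the chain end would move the number beyond the scatter.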